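Aryl Variation on the Ring Nitrogen: Outlook for Compound 4

This account rests on a few compounds, and the source may have more. Where it says the series, first, only, none or still open, it means among the compounds named here.

The series shares a core in which an aryl group sits on an aromatic nitrogen of a five-membered aromatic ring with 3 nitrogen. Compound 1 `COc1cccc(-n2cc(COc3cccc(NC(=O)Nc4ccc(Cl)c(C(F)(F)F)c4)c3)nn2)c1` carries 3-methoxyphenyl there, and in a functional assay on HepG2 cells (Homo sapiens) for inhibition, read by MTT assay, with a stated time of 72 h (on this read-out lower numbers stand for stronger inhibition and higher numbers for weaker inhibition), compound 1 gives 1310 nM. Compound 2 `Cc1ccccc1-n1cc(COc2cccc(NC(=O)Nc3ccc(Cl)c(C(F)(F)F)c3)c2)nn1` carries 2-methylphenyl, and in this assay compound 2 gives 3440 nM, the second highest of the three numbers. Compound 3 `Cc1cccc(-n2cc(COc3cccc(NC(=O)Nc4ccc(Cl)c(C(F)(F)F)c4)c3)nn2)c1` carries 3-methylphenyl, and in this assay compound 3 gives 7270 nM. The measured steps are a 2.6-fold higher number from compound 1 to compound 2 (0.42 log units; beyond the scatter), a 2.1-fold higher number from compound 2 to compound 3 (0.32 log units; beyond the scatter) and a 5.5-fold higher number from compound 1 to compound 3 (0.74 log units; beyond the scatter); all three aryl groups lie within a modest span, with compound 2 between the other two.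

Compound 4 `O=C(Nc1cccc(OCc2cn(-c3cccc(F)c3)nn2)c1)Nc1ccc(Cl)c(C(F)(F)F)c1` differs from compound 2 by 3-fluorophenyl in place of 2-methylphenyl on an aromatic nitrogen. The step from compound 2 to compound 3 and the step from compound 1 to compound 3 bear most directly on it, as each exchanges the group on the phenyl; both were modest. Going by the values given here, no measured step involves fluorine, so the direction is open, and compound 1 and compound 3 sit on either side of compound 2. For compound 4 a step of a 1.2-fold higher number from compound 2 to compound 4 (0.07 log units; within the scatter) in this assay is expected, not larger than the measured ones. Compound 4 is estimated at 4000 nM in this assay, with a range from 1500 nM to 10000 nM.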

Compound 4, half-maximal inhibitory concentration: 2120 nM
Compound 4: middle estimate off by 1.9-fold (0.28 log units), on the high side; the range from low to high includes it.
By their numbers in this assay, from the lowest: compounds 1, 4 and 2 (each within the scatter of the next, the first and the last beyond it); then compound 3.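

In this assay, a third group of the 3-substituted phenyl kind now stands on the aromatic nitrogen, and it does not read with 3-methylphenyl: the change gives a 3.4-fold lower number from compound 3 to compound 4 (0.54 log units; beyond the scatter). The other two comparisons give a 1.6-fold higher number from compound 1 to compound 4 (0.21 log units; within the scatter) and a 1.6-fold lower number from compound 2 to compound 4 (0.21 log units; within the scatter), so 3-fluorophenyl cannot be ordered against 3-methoxyphenyl or 2-methylphenyl, and these three aryl groups form one cluster in which compound 3 alone stands apart, with its steps to compounds 1, 2 and 4 all beyond the scatter. The series offers no measurement that accounts for these differences.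

As far as these compounds go, how an amine or a carboxylic acid on this phenyl group would read in this assay remains open, as does whether a longer alkoxy chain in place of the methoxy of compound 1 would stay within this cluster. Going by these compounds alone, also open is how 2-fluorophenyl would compare with 3-fluorophenyl, since the only pair here that moves one substituent around the phenyl ring is the methyl pair of compound 2 and compound 3.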